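The source may report more compounds than this note shows. Statements on the series, on what has been measured and on what is new or still open speak of the compounds shown alone.

In an ADME assay on the whole organism (plasma, strain Wistar) for pharmacokinetics, with Rattus norvegicus as the target, at a dose of 100 mg/kg by the oral route (on this read-out lower numbers stand for lower exposure and higher numbers for higher exposure at the dose given), compound 3 (`CCC(=O)NS(=O)(=O)c1ccc(-n2nc(C(F)(F)F)cc2-c2ccc(OC)c(C)c2)cc1CO`) gives 125000 ng.h/mL. Compound 1 (`NS(=O)(=O)c1ccc(-n2nc(C(F)F)cc2-c2ccc(Br)cc2)cc1CO`) gives 239000 ng.h/mL, and compound 2 (`CCC(=O)NS(=O)(=O)c1ccc(-n2nc(C(F)F)cc2-c2ccc(Br)cc2)cc1CO`) gives 289000 ng.h/mL. The value of compound 3 lies within the scatter of that of compound 1 and beyond the scatter of that of compound 2.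

Compound 4 (`CCC(=O)NS(=O)(=O)c1ccc(-n2nc(C(F)F)cc2-c2ccc(OC)c(C)c2)cc1CO`) arises from compound 3 by hydrogen in place of fluoro on a saturated chain carbon bound to an aromatic carbon and two fluorine atoms, that is, trifluoromethyl to difluoromethyl.

For the measured compounds named here, no measured step covers this change. Going by the values given here, the only single-place step, a 1.2-fold higher number from compound 1 to compound 2 (0.08 log units; within the scatter), is propanoyl in place of hydrogen on a sulfonamide nitrogen, a different change, and it stays within the scatter. Compound 1 and compound 2 carry difluoromethyl but differ from compound 3 in more than one place, so their gap to it cannot be assigned to this group alone. They offer only weak support for a slight rise.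

The expected step is small and within the scatter, a 1.3-fold higher number from compound 3 to compound 4 (0.11 log units; within the scatter). For compound 4 the estimated value is 160000 ng.h/mL, with an expected range of 80000 ng.h/mL to 320000 ng.h/mL.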

Compound 4, area under the concentration-time curve: 106000 ng.h/mL
Estimate against measurement, compound 4: 1.5-fold (0.18 log units) above; the range from low to high includes it.
By their numbers in this assay, from the lowest: compounds 4, 3, 1 and 2 (each within the scatter of the next, the first and the last beyond it).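

In this assay the change from trifluoromethyl to difluoromethyl, on a saturated chain carbon bound to an aromatic carbon and two fluorine atoms, is now read directly and gives a 1.2-fold lower number from compound 3 to compound 4 (0.07 log units; within the scatter) so this fluoro-to-hydrogen change does not separate the pair. For the compounds shown here, the modest change of 4-bromophenyl to 4-methoxy-3-methylphenyl on an aromatic carbon, with difluoromethyl and the propanoyl group on the sulfonamide nitrogen held constant, gives a 2.7-fold lower number from compound 2 to compound 4 (0.44 log units; beyond the scatter) and is the only single-place step so far beyond the scatter. No supporting data accompany either step to explain these results.

The compounds shown do not tell whether the methoxy or the methyl group carries the aryl step. They also leave open how a methyl group or a nitrile would read in place of difluoromethyl.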